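Ring size on the ether group: pyrrolidinyl to piperidinyl

The compounds below may be only part of what the source reports. "The series", "measured", "known", "first", "only" and "open" are said of these compounds alone.

Measured so far in an assay on cells for inhibition of MAP kinase-interacting serine/threonine-protein kinase 1 (Homo sapiens), read by mobility shift assay, with stated times of 10 min and 60 min, in the presence of a further agent that is not named here; on this read-out higher numbers stand for weaker inhibition and lower numbers for stronger inhibition:
compound 1 `NC(=O)c1ccc(-c2cccnc2)cc1` gives 8800 nM
compound 2 `CCNc1cc(-c2cccnc2)ccc1C(N)=O` gives 58000 nM
compound 3 `NC(=O)c1ccc(-c2cccnc2)cc1OC1CCNC1` gives 1900 nM

Compound 3 stands lowest of the three numbers in this assay. Its separation from the other two is beyond the scatter: the step of a 4.6-fold lower number from compound 1 to compound 3 (0.67 log units; beyond the scatter) and the step of a 31-fold lower number from compound 2 to compound 3 (1.48 log units; beyond the scatter) both run in the direction of stronger inhibition, whereas the step of a 6.6-fold higher number from compound 1 to compound 2 (0.82 log units; beyond the scatter) runs the other way. For the measured compounds named here, the (pyrrolidin-3-yl)oxy group therefore marks the best point so far.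

Compound 4 `NC(=O)c1ccc(-c2cccnc2)cc1OC1CCNCC1` differs from compound 3 in one place: piperidin-4-yl in place of pyrrolidin-3-yl on an oxygen on an aromatic ring. Going by the values given here, no measured step changes ring size on the ether; the steps that bear on this position only introduce the pyrrolidinyl ether or exchange it for ethylamino, and they are of modest and large size. Among the compounds with values here, a change that keeps one nitrogen-containing saturated ring on the same oxygen and adds one carbon has no direct precedent here, so the step of a 1.1-fold higher number from compound 3 to compound 4 (0.02 log units; within the scatter) is expected to stay within the scatter or close to it. Compound 4 is therefore estimated at about 2000 nM in this assay, with a range from 800 nM to 5500 nM.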

Compound 4, half-maximal inhibitory concentration: 1100 nM
Estimate against measurement, compound 4: 1.8-fold (0.26 log units) above; the range from low to high includes it.
By their numbers in this assay, from the lowest: compounds 4 and 3 (each within the scatter of the next); then compound 1; then compound 2.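

In this assay, compound 3 and compound 4 cannot be separated (a 1.7-fold lower number from compound 3 to compound 4 (0.24 log units; within the scatter)), so this position accepts either pyrrolidin-3-yl or piperidin-4-yl on the oxygen with no difference outside the scatter. The advantage of the ether is therefore not confined to the five-membered ring, as the piperidinyl ether also stands clear of the hydrogen of the unsubstituted compound (an 8.0-fold lower number from compound 1 to compound 4 (0.90 log units; beyond the scatter)) and of ethylamino (a 53-fold lower number from compound 2 to compound 4 (1.72 log units; beyond the scatter)). Among the compounds shown, both ring ethers lie on the side of stronger inhibition relative to compound 1, whereas compound 2, with ethylamino, lies on the side of weaker inhibition and goes against any general gain from a substituent here.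

An azepan-4-yl ether, a cyclohexyl ether or an open-chain 2-aminoethyl ether would show how far ring size can extend and whether the ring nitrogen or the ring itself is needed. No supporting data are available to account for the result at this position.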